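Ring substituent variation in the shared core series

The compounds below may be only part of what the source reports. "The series", "measured", "known", "first", "only" and "open" are said of these compounds alone.

Compound 3 `CCOC(=O)c1c(N)sc(/N=C/c2ccc(C)cc2)c1C(=O)OCC` carries the shared core and in a functional assay on MCF7 cells (Homo sapiens) for inhibition, read by MTT assay, with a stated time of 48 h (a higher number here means a weaker inhibitor, a lower number a stronger inhibitor), gives 8900 nM. On the numbers shown its value is the highest of the three, though every gap to the others lies within the scatter: compound 1 `CCOC(=O)c1c(N)sc(/N=C/c2ccccc2)c1C(=O)OCC` gives 6100 nM, and compound 2 `CCOC(=O)c1c(N)sc(/N=C/c2ccc(N(C)C)cc2)c1C(=O)OCC` gives 5700 nM, so no order among the three can be read.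

Compound 4 `CCOC(=O)c1c(N)sc(/N=C/c2ccc([N+](=O)[O-])cc2)c1C(=O)OCC` differs from compound 3 by nitro in place of methyl on an aromatic carbon. Among the compounds with values here, no measured step exchanges methyl for nitro. Within the data shown here, the steps that bear on it are the three at the same aromatic carbon: a 1.5-fold higher number from compound 1 to compound 3 (0.16 log units; within the scatter), a 1.6-fold higher number from compound 2 to compound 3 (0.19 log units; within the scatter) and a 1.1-fold lower number from compound 1 to compound 2 (0.03 log units; within the scatter). Each of them stayed within the scatter, so exchanging the group at this position has so far given no step beyond it. For the move to compound 4 the expectation in this assay is therefore no step beyond the scatter, estimated as a 1.3-fold lower number from compound 3 to compound 4 (0.10 log units; within the scatter). Compound 4 is expected to give 7000 nM in this assay, with a range from 3000 nM to 16000 nM.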

Compound 4, half-maximal inhibitory concentration: 1300 nM
Compound 4: middle estimate off by 5.4-fold (0.73 log units), on the high side; measured number below the stated range.
By their numbers in this assay, from the lowest: compound 4; then compounds 2, 1 and 3 (each within the scatter of the next).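

In this assay, within the data shown here, nitro at this aromatic carbon gives the first steps beyond the scatter at this position, and all three are downward (a 6.8-fold lower number from compound 3 to compound 4 (0.84 log units; beyond the scatter)) (a 4.4-fold lower number from compound 2 to compound 4 (0.64 log units; beyond the scatter)) (a 4.7-fold lower number from compound 1 to compound 4 (0.67 log units; beyond the scatter)). The position is therefore not indifferent to exchange: hydrogen, methyl and dimethylamino stay within the scatter of one another, while compound 4 stands apart from all three with the lowest number of the set. Nothing available explains why nitro separates from the other groups.

On these data alone, whether this separation is specific to nitro remains open, since a nitrile, a carboxylic acid or a chlorine at the same carbon could show whether other groups share it. As far as these compounds go, it also remains open whether the 4-methylphenyl to 4-nitrophenyl step carries over to a core with a different ester chain.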